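This account rests on a few compounds, and the source may have more. Where it says the series, first, only, none or still open, it means among the compounds named here.

Measured compounds in an assay on isolated protein for inhibition of thyroid hormone receptor alpha (Homo sapiens), read by fluorescence polarization; on this read-out lower numbers stand for stronger inhibition and higher numbers for weaker inhibition:

- compound 1 `CS(=O)(=O)c1ccc(C(=O)N2CCC(C(=O)N3CCN(c4ccc(F)cc4)CC3)CC2)cc1[N+](=O)[O-]` gives > 60000 nM, a limit of the assay.
- compound 2 `CN(Cc1cccc(F)c1)C(=O)CCCNC(=O)c1ccc(S(C)(=O)=O)c([N+](=O)[O-])c1` gives > 60000 nM, a limit of the assay.
- compound 3 `CN(Cc1ccccc1)C(=O)C1CCN(C(=O)c2ccc(S(C)(=O)=O)c([N+](=O)[O-])c2)CC1` gives > 60000 nM, a limit of the assay.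

Compound 1 stands at the limit of this assay, and no number exists for it, only the limit. The other two values shown are limits of the same kind, so nothing distinguishes the three compounds from one another; this is summed up in the limit of > 60000 nM in this assay, at which 3 of the 3 values shown sit. No ordering among compounds 1, 2 and 3 can be read from these values.

Compound 4 `Cc1ccc(N2CCN(C(=O)C3CCN(C(=O)c4ccc(S(C)(=O)=O)c([N+](=O)[O-])c4)CC3)CC2)cc1` differs from compound 1 in one place: methyl in place of fluoro on an aromatic carbon. Among the measured compounds shown here, no step between measured compounds is available for this change. With compound 1 at the limit and the change confined to a single heavy atom, the step from compound 1 to compound 4 is expected to be none beyond the scatter, as the expected step that the limit leaves unreadable from compound 1 to compound 4 shows. Compound 4 is therefore estimated at 90000 nM, with a range from 30000 nM to 300000 nM, and most likely the assay again reports only a limit.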

Compound 4, half-maximal inhibitory concentration: > 60000 nM
Compound 4 was reported as a limit; the forecaster's own chance of this, stated with the estimate: 90%; the middle value lies beyond the limit too.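

Among the compounds shown here, compound 1 and compound 4 both stand as limits in this assay and no step between them can be read, so methyl in place of fluoro shows no readable effect: the limit of > 60000 nM in this assay, at which 4 of the 4 values shown sit. The compounds shown leave open which change to the shared core, if any, would give a number in this assay rather than a limit.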